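Adding a Methoxy Group to a Cyclopropyl Thiourea

This account rests on a few compounds, and the source may have more. Where it says the series, first, only, none or still open, it means among the compounds named here.

Compound 1, `CC(C)C(NC(=S)NCc1ccc(C(C)(C)C)cc1)c1ccc(NS(C)(=O)=O)c(F)c1`, gives 223 nM in a functional assay on CHO cells for antagonist activity at transient receptor potential cation channel subfamily V member 1 (Rattus norvegicus); a lower number here means a stronger inhibitor, a higher number a weaker inhibitor.
Compound 2, `CC(C)(C)c1ccc(CNC(=S)NC2(c3ccc(NS(C)(=O)=O)cc3)CC2)cc1`, gives 60 nM in this assay.
Compound 3, `CC(C)(C)c1ccc(CNC(=S)NC(C)(C)c2ccc(NS(C)(=O)=O)c(F)c2)cc1`, gives 980 nM in this assay.

Among these three thioureas, compound 2 has the lowest number in this assay, and so is the strongest inhibitor of the set: compound 1 sits above it by a margin beyond the usual scatter, and compound 3 lies furthest away, well beyond the scatter. Compound 4, `COc1cc(C2(NC(=S)NCc3ccc(C(C)(C)C)cc3)CC2)ccc1NS(C)(=O)=O`, is built on compound 2 and differs from it only in this way: methoxy in place of hydrogen on an aromatic carbon. Among the measured compounds shown here, no pair of measured compounds isolates this change, and compounds 1 and 3 differ from compound 2 in other places as well, so they offer no direct guide to what a methoxy group does here. The step from compound 2 to compound 4 is therefore expected to be modest, more likely toward a higher number than a lower one, and possibly not beyond the scatter: a 2.0-fold higher number from compound 2 to compound 4 (0.30 log units; within the scatter). Compound 4 is estimated to give about 120 nM in this assay, with a plausible range from 35 nM to 400 nM.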

Compound 4, inhibition constant: 243 nM
Compound 4: middle estimate off by 2.0-fold (0.31 log units), on the low side, and the stated range covers the measured number.
By their numbers in this assay, from the lowest: compound 2; then compounds 1 and 4 (each within the scatter of the next); then compound 3.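

In this assay, among the compounds shown here, methoxy in place of hydrogen on the aromatic carbon ortho to the methanesulfonamido group gives a 4.1-fold higher number from compound 2 to compound 4 (0.61 log units; beyond the scatter), the first comparison in this set that changes only one place. This shows that the position is not indifferent to substitution: on this cyclopropyl thiourea, adding a methoxy group of only 2 heavy atoms is enough to give a clearly weaker inhibitor. No measurement shown here accounts for the loss, so the result records the size of the change and offers no explanation for it.

On these data alone, what stays open is whether the loss is specific to methoxy or would follow from other groups on the same carbon, and a hydroxyl group, a chlorine atom or an ethoxy group there would help separate those possibilities. It is also unknown whether methoxy would have a similar effect on the thioureas of compound 1 or compound 3; each differs from compound 2 in more than one place, so neither can serve as a guide.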